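This account rests on a few compounds, and the source may have more. Where it says the series, first, only, none or still open, it means among the compounds named here.

Measured compounds in a physicochemical assay for lipophilicity; on this read-out higher numbers stand for higher lipophilicity and lower numbers for lower lipophilicity:
compound 1 `CC1(C)CC(NC(=O)C(/C=C/[C@@H](NC(=O)OC(C)(C)C)c2ccc(F)cc2)(Cc2ccc(F)cc2)Cc2ccc(F)cc2)CC(C)(C)N1`: 7.9
compound 2 `CC(C)C[C@H](/C=C/C(Cc1ccc(F)cc1)(Cc1ccc(F)cc1)C(=O)NC1CC(C)(C)NC(C)(C)C1)NC(=O)OC(C)(C)C`: 7.6

Compound 2 and compound 1 lie within the usual scatter of one another in this assay, so the two numbers do not separate them. Compound 3 `CC(C)C[C@@H](/C=C/C(Cc1ccc(F)cc1)(Cc1ccc(F)cc1)C(=O)NC1CC(C)(C)NC(C)(C)C1)NC(=O)OC(C)(C)C` is not yet measured. It differs from compound 2 as follows: the two compounds have the same atoms and bonds and differ only in configuration as drawn: 1 of 2 stereo elements differ; a stereocentre at a saturated chain carbon is drawn R in compound 2 and S in compound 3. Within the data shown here, no measured pair with a matching change is available. A change of configuration alone gives no ground to expect a shift in this assay beyond the scatter in either direction. Compound 3 is therefore expected near 7.6, with a range of 7.3 to 7.9. This estimate means a step of no change at the digits printed from compound 2 to compound 3 (within the scatter).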

Compound 3, partition coefficient: 7.6
For compound 3 middle estimate and measured number coincide at the digits printed; the range from low to high includes it.
By their numbers in this assay, from the lowest: compounds 2, 3 and 1 (each within the scatter of the next).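

Among these compounds, changing only the drawn configuration at the saturated chain carbon bearing isobutyl gives no change at the digits printed from compound 2 to compound 3 (within the scatter) in this assay, a reading of this stereocentre alone that the earlier compounds did not offer: the fact that compounds 2 and 3 differ only in the configuration as drawn. Isobutyl in place of 4-fluorophenyl on that carbon gives a number 0.30 log units lower from compound 1 to compound 3 (within the scatter), so neither change at this position separates the compounds in this assay.

From the compounds shown here alone, whether a carboxylic acid or a primary amine on this carbon would move the number beyond the scatter stays open. So does the effect of configuration with 4-fluorophenyl there.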